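The source may report more compounds than this note shows. Statements on the series, on what has been measured and on what is new or still open speak of the compounds shown alone.

In a functional assay on brain (Rattus norvegicus, strain Wistar) for inhibition (a higher number here means a weaker inhibitor, a lower number a stronger inhibitor), compound 1 (`COc1ccc(-c2c(C)[nH]c(=O)n2C2CCCCC2)cc1`) stands at 20400 nM and compound 2 (`CCCCCOc1ccc(-c2c(C)[nH]c(=O)n2C2CCCCC2)cc1`) at 9100 nM, while compound 3 (`CCCCCCCOc1ccc(-c2c(C)[nH]c(=O)n2C2CCCCC2)cc1`) stands at 11600 nM and so lies within the scatter of both. Compound 4 (`CCCCCCCCCCOc1ccc(-c2c(C)[nH]c(=O)n2C2CCCCC2)cc1`) differs from compound 3 by propyl in place of hydrogen on a saturated chain carbon, seven bonds along the chain from an oxygen on an aromatic ring and so carries a longer chain on the same oxygen. The closest guides are the earlier chain lengthenings a 1.3-fold higher number from compound 2 to compound 3 (0.11 log units; within the scatter) and a 1.8-fold lower number from compound 1 to compound 3 (0.25 log units; within the scatter) and neither leaves the scatter, while a 2.2-fold lower number from compound 1 to compound 2 (0.35 log units; beyond the scatter) is only modest. In this assay no step beyond the scatter is therefore expected, and the estimated change is small (a 1.2-fold lower number from compound 3 to compound 4 (0.06 log units; within the scatter)). For compound 4 the expected value is about 10000 nM (estimated range 4500 nM to 25000 nM).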

Compound 4, half-maximal inhibitory concentration: 10500 nM
The estimate for compound 4 lay 1.1-fold (0.02 log units) below the measured number; low and high end bracket the measured number.
By their numbers in this assay, from the lowest: compounds 2, 4, 3 and 1 (each within the scatter of the next, the first and the last beyond it).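

Lengthening the chain on the oxygen beyond the earlier compounds leaves the number in this assay essentially level, with a 1.1-fold lower number from compound 3 to compound 4 (0.04 log units; within the scatter) and a 1.2-fold higher number from compound 2 to compound 4 (0.06 log units; within the scatter) both staying within the scatter. Even the whole stretch from the shortest chain to the longest one shown, a 1.9-fold lower number from compound 1 to compound 4 (0.29 log units; within the scatter) in size, stays within the scatter, so this position accepts a much longer chain with no measurable loss of inhibition.

From the compounds shown here alone, whether an amine or a carboxylic acid on this chain would move the number stays open. No available measurement explains why the numbers stay level.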